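The source may hold more compounds than are shown below. What is called first, only, known or untested is meant among the compounds shown, and "the series" means these compounds.

The account follows a set built on a shared core, that of compound 1 `O=C(Nc1ccc(Cl)c(-c2nnc3c(Cl)cccn23)c1)c1ccccc1`. For the measured compounds named here, in a functional assay on A549 cells (Homo sapiens) for antiproliferative activity, read by MTT assay, with a stated time of 72 h (a higher number here means a weaker inhibitor, a lower number a stronger inhibitor), compound 1 gives 76900 nM, the only number among the three values known. Compound 2 `Cc1cc(Cl)ccc1C(=O)Nc1ccc(Cl)c(-c2nnc3c(Cl)cccn23)c1` reaches only the limit of > 100000 nM in this assay. Compound 3 `CS(=O)(=O)c1cccc(C(=O)Nc2ccc(Cl)c(-c3nnc4c(Cl)cccn34)c2)c1` likewise reaches only the limit of > 100000 nM in this assay. Both steps away from compound 1 therefore read as floors, an at least 1.3-fold higher number from compound 1 to compound 2 (0.11 log units; that floor lies within the scatter) and an at least 1.3-fold higher number from compound 1 to compound 3 (0.11 log units; that floor lies within the scatter), both set by the limit of > 100000 nM in this assay, at which 2 of the 3 values shown sit. Compound 4 `O=C(Nc1ccc(Cl)c(-c2nnc3c(Cl)cccn23)c1)c1ccccn1` is not yet measured; it differs from compound 1 by pyridin-2-yl in place of phenyl on a carbonyl carbon. Going by the values given here, no measured step alters the benzoyl end in this way, and the two steps that do touch it read only as floors lying within the scatter. In this assay the expected step is a 1.2-fold higher number from compound 1 to compound 4 (0.07 log units; within the scatter), which is expected to remain within the scatter. Compound 4 is expected at 90000 nM, between 40000 nM and 200000 nM.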

Compound 4, half-maximal inhibitory concentration: > 100000 nM
Compound 4: a limit, no number; the forecaster's own chance of this, stated with the estimate: 40%; middle value at least 1.1-fold (0.04 log units) from the limit.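

Compound 4 gives only a limit in this assay, > 100000 nM. Pyridin-2-yl in place of phenyl on a carbonyl carbon exchanges an atom of the ring itself, where compound 2 and compound 3 carry added groups on the phenyl ring, and this different kind of change also reads only as a floor, an at least 1.3-fold higher number from compound 1 to compound 4 (0.11 log units; that floor lies within the scatter). The steps linking compound 4 to compound 2 and to compound 3 cannot be read, and compound 1 remains the only compound with a number: the limit of > 100000 nM in this assay, at which 3 of the 4 values shown sit.

On these data alone, whether an amine or a carboxylic acid on the benzoyl ring would bring a readable value in this assay stays open. So does the outcome for pyridin-3-yl or a morpholine ring on the same carbonyl carbon.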